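Solubility of Three Indole Analogues and an Untested Fourth

A few compounds are considered here, and "the series" means these few. Any claim that something is new, unique, unknown or untested is made for them only; others in the source may bear on it.

Three compounds bearing a piperidin-4-yl on a fused indole core were examined in a physicochemical assay for solubility, in phosphate buffer, at pH 7.4; on this read-out lower numbers stand for lower solubility and higher numbers for higher solubility. Compound 1 `Fc1ccc(Nc2ccc3c(C4CCNCC4)c[nH]c3n2)cc1F` gives 176000 nM in this assay. Compound 2 `c1cc2c(C3CCNCC3)c[nH]c2cc1Nc1ccc2[nH]cc(C3CCNCC3)c2c1` gives 153000 nM. Compound 3 `N#Cc1c[nH]c2nc(Nc3ccc4c(C5CCNCC5)c[nH]c4c3)ccc12` gives 196000 nM, a number that sits within the usual scatter of both compound 1 and compound 2, so no ordering among the three can be claimed.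

Compound 4 `c1cc2c(C3CCNCC3)c[nH]c2cc1Nc1ccc2c(C3CCNCC3)c[nH]c2n1` has not yet been measured in this assay. It differs from compound 3 in one place: piperidin-4-yl in place of cyano on an aromatic carbon. The cyano leaves, carrying one hydrogen-bond acceptor and no donor, and a piperidin-4-yl enters, a six-membered non-aromatic ring with one hydrogen-bond donor and one acceptor. Compound 2, which carries two piperidin-4-yl groups, and compound 3, which carries one, lie within the scatter of each other, so no step beyond the scatter is expected from compound 3 to compound 4, and the estimated change is a 1.2-fold lower number from compound 3 to compound 4 (0.07 log units; within the scatter). Compound 4 is expected to give about 165000 nM, with a likely range from 90000 nM to 300000 nM.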

Compound 4, solubility: 166000 nM
The estimate for compound 4 lay 1.0-fold (0.00 log units) below the measured number, and the stated range covers the measured number.
By their numbers in this assay, from the lowest: compounds 2, 4, 1 and 3 (each within the scatter of the next).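

Placing piperidin-4-yl in place of cyano on an aromatic carbon of the five-membered aromatic ring gives the first step that can be read between two compounds differing in one place: in this assay it is a 1.2-fold lower number from compound 3 to compound 4 (0.07 log units; within the scatter) for this change. At this position, two ring bonds from the ring nitrogen, a six-membered non-aromatic ring and a nitrile thus give numbers within the scatter of each other, even though the entering group brings a hydrogen-bond donor that cyano lacks. Nothing measured here bears on why this is so.

From the compounds shown here alone, whether a carboxylic acid, a primary amine or a longer alkyl chain at this place would also stay within the scatter remains open. So does whether the same exchange would give a step of similar size on the core of compound 1.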